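Benzyloxy Carbamate Expected Past the Lipophilicity Ceiling

A few compounds are considered here, and "the series" means these few. Any claim that something is new, unique, unknown or untested is made for them only; others in the source may bear on it.

In a physicochemical assay for lipophilicity, at pH 7.4 (a lower number here means a more polar compound, a higher number a more lipophilic compound), three compounds have been measured, each reported only as a limit of the assay:
compound 1 `Cc1cc(C(=O)NC(C)C)nn1Cc1cc(Cl)ccc1OCc1ccccc1` gives > 3.7
compound 2 `Cc1cc(NC(=O)CC(C)(C)C)nn1Cc1cc(Cl)ccc1OCc1ccccc1` gives > 3.7
compound 3 `Cc1cc(NC(=O)C2CCOC2)nn1Cc1cc(Cl)ccc1OCc1ccccc1` gives > 3.7

Compound 3 therefore stands at the ceiling of this assay, and it is not alone there: the limit of > 3.7 in this assay, at which 3 of the 3 values shown sit. Because all three values are limits, none of the steps between them can be sized: a step that the two limits leave unreadable from compound 1 to compound 2, a step that the two limits leave unreadable from compound 1 to compound 3, a step that the two limits leave unreadable from compound 2 to compound 3.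

Compound 4 `Cc1cc(NC(=O)OCc2ccccc2)nn1Cc1cc(Cl)ccc1OCc1ccccc1` differs from compound 3 at the carbonyl carbon of the amide: benzyloxy in place of oxolan-3-yl on a carbonyl carbon. No measured step bears readably on this exchange, so the size of the change cannot be anchored in the numbers shown. What is known is that compound 3 already sits at the limit, and the incoming group is the larger of the two by heavy-atom count.

The expectation is that compound 4 will again be reported as a limit in this assay, an estimated 4.6 with a range from 3.7 to 5.5. The expected step from compound 3 to compound 4 is therefore a step that the limit leaves unreadable from compound 3 to compound 4, which cannot be confirmed by the assay if both sit at its ceiling.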

Compound 4, distribution coefficient: 3.1
For compound 4 the middle estimate is 1.50 log units above the measured one; measured number below the stated range.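

At the carbonyl carbon, this exchange gives the position its first sized changes in this assay: a number at least 0.60 log units lower from compound 3 to compound 4 (beyond the scatter), a number at least 0.60 log units lower from compound 2 to compound 4 (beyond the scatter), and a number at least 0.60 log units lower from compound 1 to compound 4 (beyond the scatter). Swapping oxolan-3-yl for benzyloxy adds heavy atoms, yet the reading falls, so a larger group at this position does not by itself keep a compound at the limit. The steps among compound 1, compound 2 and compound 3 cannot be read, and the new steps give only minimum sizes, because those three compounds all sit at the limit: the limit of > 3.7 in this assay, at which 3 of the 4 values shown sit.

On these data alone, the full size of each fall remains unknown. As far as these compounds go, it also remains open whether the fall would persist with a plain benzyl or a methoxy group on the same carbonyl carbon, which would help show whether the ring or the linking oxygen of benzyloxy goes with it.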